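Chloro in place of fluoro on the benzyl group

The compounds below may be only part of what the source reports. "The series", "measured", "known", "first", "only" and "open" are said of these compounds alone.

compound 1 (`N#Cc1cc2c(nc1N1CCC(F)(C(=O)NS(=O)(=O)Cc3ccc(Cl)cc3)CC1)COC2=O`) gives 37200 nM
compound 2 (`CC1(C(=O)NS(=O)(=O)Cc2ccc(F)cc2)CCN(c2nc3c(cc2C#N)C(=O)OC3)CC1`) gives 35400 nM

Going by the values given here, in a functional assay (Platelet, plasma) for inhibition, with Homo sapiens as the target (on this read-out lower numbers stand for stronger inhibition and higher numbers for weaker inhibition), compound 2 (35400 nM) stands within the scatter of compound 1 (37200 nM), the only other measured compound. Compound 3 (`CC1(C(=O)NS(=O)(=O)Cc2ccc(Cl)cc2)CCN(c2nc3c(cc2C#N)C(=O)OC3)CC1`) is compound 2 with chloro in place of fluoro on an aromatic carbon, para to a large group (chloro in place of fluoro on an aromatic carbon). Among the compounds with values here, no measured pair isolates this change. Compound 1 (37200 nM) already carries the 4-chlorobenzyl group, so no step beyond the scatter is expected in this assay, and no direction is favoured. The estimated change is the (a 1.1-fold lower number from compound 2 to compound 3 (0.03 log units; within the scatter)). For compound 3 the expected value is 33000 nM (estimated range 14000 nM to 75000 nM).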

Compound 3, half-maximal inhibitory concentration: 3010 nM
Beside the measured number, compound 3's estimate is 11-fold (1.04 log units) above it, outside the stated range (below it).
By their numbers in this assay, from the lowest: compound 3; then compounds 2 and 1 (each within the scatter of the next).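

In this assay, the 4-fluorobenzyl to 4-chlorobenzyl change is not neutral on the methyl-bearing compounds: it gives a 12-fold lower number from compound 2 to compound 3 (1.07 log units; beyond the scatter). The 4-chlorobenzyl group alone does not set the low number, since methyl in place of fluoro on the saturated ring carbon gives a 12-fold lower number from compound 1 to compound 3 (1.09 log units; beyond the scatter), so the result depends on both places. No available evidence accounts for this result.

On these data alone, whether bromo or methoxy on the aromatic carbon would match chloro remains open. So does whether ethyl or hydroxy on the saturated ring carbon would match methyl.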